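This account rests on a few compounds, and the source may have more. Where it says the series, first, only, none or still open, it means among the compounds named here.

Compound 1 `Cc1ccccc1-n1nncc1CN1C(=O)C2(C(C#N)=C(N)Oc3c2c2nc4ccccc4nc2c2ccccc32)c2ccccc21` — a limit, > 50000 nM, in an ADME assay on HUVEC cells (Homo sapiens) for antiproliferative activity, read by MTT assay, with a stated time of 48 h; on this read-out higher numbers stand for weaker inhibition and lower numbers for stronger inhibition
Compound 2 `N#CC1=C(N)Oc2c(c3nc4ccccc4nc3c3ccccc23)C12C(=O)N(Cc1cnnn1-c1ccc(Br)cc1)c1ccccc12` — a limit, > 50000 nM
Compound 3 `N#CC1=C(N)Oc2c(c3nc4ccccc4nc3c3ccccc23)C12C(=O)N(Cc1cnnn1-c1ccccc1Br)c1ccccc12` — a limit, > 50000 nM

Compound 1 stands at the limit of this assay, and so do compound 2 and compound 3; none of the three has a number, only (the limit of > 50000 nM in this assay, at which 3 of the 3 values shown sit). The three steps between them, a step that the two limits leave unreadable from compound 1 to compound 2, a step that the two limits leave unreadable from compound 1 to compound 3 and a step that the two limits leave unreadable from compound 2 to compound 3, cannot be read. Every value is hidden behind the same limit; it is not known whether swapping the group on the triazole nitrogen changed anything.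

Compound 4 `CCOc1ccccc1-n1nncc1CN1C(=O)C2(C(C#N)=C(N)Oc3c2c2nc4ccccc4nc2c2ccccc32)c2ccccc21` differs from compound 1 in one place: ethoxy in place of methyl on an aromatic carbon. Among the compounds with values here, no measured step bears directly on this change, and the steps that are known are all unreadable, so they give no direction to expect. Within the data shown here, the only guide is that every measured compound sits at the limit, including compound 1, whose value is > 50000 nM.

Compound 4 is therefore expected to sit at the limit as well, with an estimate of 60000 nM and a range from 20000 nM to 200000 nM. The step from compound 1 to compound 4 is expected to be a step that the limit leaves unreadable from compound 1 to compound 4, that is, no change that the limit would let anyone read.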

Compound 4, half-maximal inhibitory concentration: > 50000 nM
Compound 4: no number, only a limit (the forecaster's own chance of this, stated with the estimate: 80%); the middle value is on the limit's open side.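

Compound 4, like compound 1, compound 2 and compound 3, gives only a limit in this assay, so no step among these four compounds can be read: the limit of > 50000 nM in this assay, at which 4 of the 4 values shown sit.

Going by these compounds, whether the 2-methylphenyl, 4-bromophenyl, 2-bromophenyl and 2-ethoxyphenyl groups differ at all in this assay stays open, as does the true value of each compound.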